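A few compounds are considered here, and "the series" means these few. Any claim that something is new, unique, unknown or untested is made for them only; others in the source may bear on it.

Measured so far in a functional assay on HCT-116 cells (Homo sapiens) for inhibition, read by MTT assay, with a stated time of 48 h; a lower number here means a stronger inhibitor, a higher number a weaker inhibitor:
- compound 1 `COc1ccc(-n2c(SCc3ccc(C)cc3)nnc2-c2cc(OC)c(OC)c(OC)c2)cc1`: 33300 nM
- compound 2 `COc1ccc(-n2c(SCC(=O)c3ccccc3)nnc2-c2cc(OC)c(OC)c(OC)c2)cc1`: > 60000 nM (a limit)
- compound 3 `COc1ccc(-n2c(SCC(=O)c3ccc(F)cc3)nnc2-c2cc(OC)c(OC)c(OC)c2)cc1`: > 60000 nM (a limit)

Compound 2 has no number, only a limit. Within the data shown here, it sits at the limit of > 60000 nM in this assay, at which 2 of the 3 values shown sit, and the one further compound there is compound 3. Only compound 1 has a measured number.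

Compound 4 `CCOC(=O)CSc1nnc(-c2cc(OC)c(OC)c(OC)c2)n1-c1ccc(OC)cc1` has not yet been measured. It differs from compound 2 as follows: ethoxy in place of phenyl on a carbonyl carbon. In short, the benzoyl group of compound 2 gives way to ethoxycarbonyl in compound 4.

Among the measured compounds shown here, three measured steps bear on this side chain. Two of them introduce the carbonyl group: an at least 1.8-fold higher number from compound 1 to compound 2 (0.25 log units; that floor lies within the scatter) and an at least 1.8-fold higher number from compound 1 to compound 3 (0.25 log units; that floor lies within the scatter). The third is a fluoro in place of hydrogen on an aromatic carbon, and it gives a step that the two limits leave unreadable from compound 2 to compound 3. None of them replaces the phenyl ring by ethoxy, so none gives a direct size for this change.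

No step beyond the scatter is therefore expected in this assay, and no direction can be read from these data. The expected size is an at least 1.2-fold lower number from compound 2 to compound 4 (0.07 log units; that floor lies within the scatter). For compound 4 the estimated value is 50000 nM, with an expected range from 20000 nM to 120000 nM.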

Compound 4, half-maximal inhibitory concentration: > 60000 nM
Compound 4 ended at the assay's limit (the forecaster's own chance of this, stated with the estimate: 50%); middle value at least 1.2-fold (0.07 log units) from the limit.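

With ethoxycarbonyl on the saturated chain carbon bound to a sulfur, the carbonyl series now has a member with no ring on the carbonyl carbon, and in this assay compound 4 still gives only a limit, > 60000 nM. The steps from compound 2 and from compound 3 to compound 4 cannot be read, since each pair has a limit at both ends, so the swap of phenyl for ethoxy has no measurable size here, and the three carbonyl compounds stand together: the limit of > 60000 nM in this assay, at which 3 of the 4 values shown sit.

Among these compounds, the one step that can be read is an at least 1.8-fold higher number from compound 1 to compound 4 (0.25 log units; that floor lies within the scatter), which leaves compound 1, with its 4-methylphenyl group, as the only compound with a measured number.

From the compounds shown here alone, how far compound 2, compound 3 and compound 4 truly lie from one another stays open, as does whether any side chain with a carbonyl can give a measured number in this assay. Also open, going by these compounds, is what a carboxylic acid, an amide or a plain longer alkyl chain would give on the same sulfur.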